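Series notes: chloro to trifluoromethyl on the fused core

A few compounds are considered here, and "the series" means these few. Any claim that something is new, unique, unknown or untested is made for them only; others in the source may bear on it.

Measured compounds:
compound 1 `CC(=O)c1ccc(N2CCN(C(=O)c3nc4cc(Cl)ccc4s3)CC2)cc1`, 30.8%
compound 2 `O=C(c1nc2cc(Cl)ccc2s1)N1CCN(c2ccccc2)CC1`, 41.2%
compound 3 `COc1ccccc1N1CCN(C(=O)c2nc3cc(Cl)ccc3s2)CC1`, 63.4%

In an ADME assay on RAW264.7 cells (Mus musculus) for cytotoxicity, read by MTT assay, with a stated time of 72 h, tested at 50 ug/mL (a lower number here means less inhibition, a higher number more inhibition at the concentration tested (going by the name of the read-out)), compound 1 stands lowest of the three. Compound 2 lies nearest, a number 10.4 percentage points higher from compound 1 to compound 2 (beyond the scatter); compound 3 lies furthest, a number 32.6 percentage points higher from compound 1 to compound 3 (beyond the scatter). Between the other two, a number 22.2 percentage points higher from compound 2 to compound 3 (beyond the scatter).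

Compound 4 `CC(=O)c1ccc(N2CCN(C(=O)c3nc4cc(C(F)(F)F)ccc4s3)CC2)cc1` differs from compound 1 only on the fused core: trifluoromethyl in place of chloro on an aromatic carbon. Among the compounds with values here, none of the measured steps bears on this place; all three alter the aryl group on the ring amine, leaving the fused core untouched. Within the data shown here, no step therefore sets an expectation of a change in this assay, and a step within the scatter is expected, in no set direction.

The estimate for compound 4 is 32%, range 16% to 50%, a step expected to be a number 1.2 percentage points higher from compound 1 to compound 4 (within the scatter).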

Compound 4, a percentage reported as inhibition, at one concentration (the size of the read-out at that concentration, not a potency): 30.6%
Beside the measured number, compound 4's estimate is 1.4 percentage points above it, and the stated range covers the measured number.
By their numbers in this assay, from the lowest: compounds 4 and 1 (each within the scatter of the next); then compound 2; then compound 3.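

In this assay, the only step shown on the fused core gives a number 0.2 percentage points lower from compound 1 to compound 4 (within the scatter), so trifluoromethyl in place of chloro on this aromatic carbon leaves the read-out within the scatter when 4-acetylphenyl sits on the ring amine. Unlike the earlier steps, all made on that aryl group and all beyond the scatter, this change produces no readable difference. Nothing measured here offers an account of that result.

As far as these compounds go, whether the same change stays within the scatter with phenyl or 2-methoxyphenyl on the ring amine remains open. So does the effect of an amine or a carboxylic acid on this aromatic carbon.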